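Same aryl swap on a longer amine chain

The source may report more compounds than this note shows. Statements on the series, on what has been measured and on what is new or still open speak of the compounds shown alone.

Compound 1 `CN(C)CCn1cnnc1-c1cc(Oc2ccc(NC(=O)Nc3ccccc3C(F)(F)F)cc2F)ccn1` and compound 2 `CN(C)CCn1cnnc1-c1cc(Oc2ccc(NC(=O)Nc3ccc(F)c(F)c3)cc2F)ccn1` share a core and differ only in the group on an amide-type nitrogen, where compound 2 carries 3,4-difluorophenyl in place of 2-(trifluoromethyl)phenyl on an amide-type nitrogen. In an assay on isolated protein for inhibition of proto-oncogene tyrosine-protein kinase receptor Ret (Homo sapiens), read by mobility shift assay, with a stated time of 1 h, tested at 10 uM (on this read-out lower numbers stand for less inhibition and higher numbers for more inhibition at the one concentration tested (going by the name of the read-out)), compound 1 gives 43%, while compound 2 gives 17.6%, so that a number 25.4 percentage points lower from compound 1 to compound 2 (beyond the scatter). Compound 3 `CN(C)CCCn1cnnc1-c1cc(Oc2ccc(NC(=O)Nc3ccccc3C(F)(F)F)cc2F)ccn1` differs from compound 1 in its core, namely ((dimethylamino)methyl in place of dimethylamino on a saturated chain carbon, two bonds along the chain from an aromatic nitrogen), and in this assay compound 3 gives "not determined" (no result reported), so no single number is known for it . Compound 4 `CN(C)CCCn1cnnc1-c1cc(Oc2ccc(NC(=O)Nc3ccc(F)c(F)c3)cc2F)ccn1` stands to compound 3 as compound 2 stands to compound 1: the change from compound 3 to compound 4 is 3,4-difluorophenyl in place of 2-(trifluoromethyl)phenyl on an amide-type nitrogen, the same change as before, made on the core of compound 3. Since compound 3 has no value, the expectation for compound 4 can rest only on the step from compound 1 to compound 2 and on the assumption that the core of compound 3 behaves like that of compound 1. On that basis the value of compound 4 in this assay is estimated at 18%, expected between 2% and 45%.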

Compound 4, a percentage reported as inhibition, at one concentration (the size of the read-out at that concentration, not a potency): 30.9%
Compound 4: middle estimate off by 12.9 percentage points, on the low side; the range from low to high includes it.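

In this assay the change of core, read with the 3,4-difluorophenyl group held fixed, gives a number 13.3 percentage points higher from compound 2 to compound 4 (beyond the scatter), which shows that the longer amine chain does not behave like the shorter one in this pair and that the core of compound 1 cannot simply stand in for the core of compound 3. Whether the aryl swap, which gave a number 25.4 percentage points lower from compound 1 to compound 2 (beyond the scatter) on the shorter chain, carries over to the longer chain in size or even in direction cannot be read: compound 3 has no value, and a single pair cannot establish a trend. No measurement shown bears on why the two cores differ.

The compounds shown leave open whether the longer chain also changes the read-out when the 2-(trifluoromethyl)phenyl group is present. A morpholine or pyrrolidine in place of dimethylamino, or a still longer chain, would show whether the step follows the chain length or depends on the amine at its end.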